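Removing the chloro group from a compound at the limit

The source may report more compounds than this note shows. Statements on the series, on what has been measured and on what is new or still open speak of the compounds shown alone.

In a functional assay on K562 cells (Homo sapiens) for cytotoxicity, read by MTT assay, with a stated time of 48 h (a higher number here means a weaker inhibitor, a lower number a stronger inhibitor), compound 1 (`COc1cc([C@@H]2C[C@@]2(CO)C(=O)Nc2ccccc2)cc(OC)c1OC`) gives > 100000 nM as its result, which is a limit and not a number. Compound 2 (`COc1cc([C@H]2C[C@]2(CO)C(=O)Nc2ccccc2Cl)cc(OC)c1OC`) gives > 100000 nM as its result, and this too is a limit and not a number. Compound 2 therefore has no measured number, and the record so far amounts to the limit of > 100000 nM in this assay, at which 2 of the 2 values shown sit, and nothing finer.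

Compound 3 (`COc1cc([C@H]2C[C@]2(CO)C(=O)Nc2ccccc2)cc(OC)c1OC`) has not yet been measured. It differs from compound 2 by having hydrogen in place of chloro on an aromatic carbon, ortho to a large group, so that 2-chlorophenyl becomes phenyl (hydrogen in place of chloro on an aromatic carbon).

Within the data shown here, no step between measured compounds is available to size this change. No step beyond the scatter is expected in this assay, and no direction is favoured. This expectation starts from compound 2 with > 100000 nM as its limit. The estimated step runs a number no higher from compound 2 to compound 3 (the limit leaves the size open) and is expected to stay small. For compound 3 the estimated value is 100000 nM, with an expected range from 50000 nM to 200000 nM in the measurement.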

Compound 3, half-maximal inhibitory concentration: > 100000 nM
Compound 3 ended at the assay's limit; the forecaster's own chance of this, stated with the estimate: 80%; the middle value lies on the limit itself.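

In this assay, compound 3 gives > 100000 nM, which is a limit and not a number. No step can be read from compound 2 to compound 3 or from compound 1 to compound 3, as all three compounds sit at one limit: the limit of > 100000 nM in this assay, at which 3 of the 3 values shown sit.

As far as these compounds go, whether the chloro group or the configuration as drawn has any effect on this result remains open.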